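From Branched to Linear Amine Chain on the Shared Core

A few compounds are considered here, and "the series" means these few. Any claim that something is new, unique, unknown or untested is made for them only; others in the source may bear on it.

Compound 2 `CC(C)(CN)Oc1ccc([C@H]2CC[C@]3(CC2)OOC2(O3)C3CC4CC(C3)CC2C4)cc1` carries a 1-(aminomethyl)-1-methylethyl group on an oxygen on an aromatic ring of the shared core. In an ADME assay on microsomes from liver (Homo sapiens) for metabolic stability, read by LC-MS, tested at 1 uM (a lower number here means slower removal, a higher number faster removal of the compound), compound 2 gives < 7 mL.min-1.g-1, which is a limit of the assay rather than a number. Its two neighbours in the set stand the same way. Compound 1 `N[C@H]1CC[C@@H](Oc2ccc([C@H]3CC[C@]4(CC3)OOC3(O4)C4CC5CC(C4)CC3C5)cc2)CC1`, bearing 4-aminocyclohexyl at that oxygen, gives < 7 mL.min-1.g-1 in this assay, again a limit. Compound 3 `NCCOCCOc1ccc([C@H]2CC[C@]3(CC2)OOC2(O3)C3CC4CC(C3)CC2C4)cc1`, with 2-(2-aminoethoxy)ethyl there, gives < 7 mL.min-1.g-1 in this assay, also a limit. Because the limit of < 7 mL.min-1.g-1 in this assay, at which 3 of the 3 values shown sit, holds for all three, the steps among them cannot be sized: a step that the two limits leave unreadable from compound 1 to compound 2, a step that the two limits leave unreadable from compound 2 to compound 3 and a step that the two limits leave unreadable from compound 1 to compound 3.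

Compound 4 `NCCCCOc1ccc([C@H]2CC[C@]3(CC2)OOC2(O3)C3CC4CC(C3)CC2C4)cc1` differs from compound 2 in one place: 4-aminobutyl in place of 1-(aminomethyl)-1-methylethyl on an oxygen on an aromatic ring. The measured steps that start from compound 2 give no readable size, so no direction can be drawn from them; what they do show is that the 4-aminocyclohexyl, 1-(aminomethyl)-1-methylethyl and 2-(2-aminoethoxy)ethyl arms all sit at the limit. The expected step from compound 2 to compound 4 is therefore a step that the limit leaves unreadable from compound 2 to compound 4, meaning nothing beyond the scatter, with a fair chance that compound 4 is again reported only as a limit. The estimate for compound 4 in this assay is 5 mL.min-1.g-1, ranging from 2 mL.min-1.g-1 to 12 mL.min-1.g-1.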

Compound 4, intrinsic clearance in microsomes: < 7 mL.min-1.g-1
Compound 4: no number, only a limit; the forecaster's own chance of this, stated with the estimate: 70%; the middle value lies beyond the limit too.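

Compound 4 gives < 7 mL.min-1.g-1 in this assay, which is a limit and not a number. For the compounds shown here, no step linking compound 4 to compound 1, compound 2 or compound 3 can be read, and all four stand the same way: the limit of < 7 mL.min-1.g-1 in this assay, at which 4 of the 4 values shown sit. The compounds shown leave open whether these four arms on the shared core differ at all in this assay.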